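A few compounds are considered here, and "the series" means these few. Any claim that something is new, unique, unknown or untested is made for them only; others in the source may bear on it.

Measured so far in a functional assay on KBVIN cells (Homo sapiens) for antiproliferative activity, read by sulforhodamine B assay, with a stated time of 3 days; a lower number here means that less compound is needed, a higher number that more compound is needed for the effect:
- Compound 1 `CCC1=C(O)c2c(oc(-c3cccc(F)c3)cc2=O)C(CC)(CC)C1=O`: 3.09 uM
- Compound 2 `CCC1=C(O)c2c(oc(-c3ccc(C)c(F)c3)cc2=O)C(CC)(CC)C1=O`: 2.95 uM

Among the measured compounds shown here, only two numbers exist so far, and compound 2 cannot be told apart from the other one: a 1.0-fold lower number from compound 1 to compound 2 (0.02 log units; within the scatter) lies within the scatter of repeated measurements. That step was methyl in place of hydrogen on an aromatic carbon.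

The next compound is compound 3 `CCC1=C(O)c2c(oc(-c3ccc(OC)c(C)c3)cc2=O)C(CC)(CC)C1=O`. The change is 4-methoxy-3-methylphenyl in place of 3-fluoro-4-methylphenyl on an aromatic carbon. So the fluorine carried by both measured compounds is gone, and a methoxy group appears for the first time.

For the measured compounds named here, only one measured step bears on this, and only loosely. A methyl group made no visible difference in a 1.0-fold lower number from compound 1 to compound 2 (0.02 log units; within the scatter), and compound 3 still carries a methyl. Going by the values given here, no measured pair shows what a methoxy group or the loss of fluorine does here, so the direction cannot be judged. No shift beyond the scatter is expected in this assay, though with so little data the range must stay wide.

The expected change is a 1.2-fold lower number from compound 2 to compound 3 (0.07 log units; within the scatter). For compound 3 the estimated value is 2.5 uM, with an expected range from 0.9 uM to 7 uM.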

Compound 3, concentration for half-maximal effect: 0.1 uM
Compound 3: middle estimate off by 25-fold (1.40 log units), on the high side, outside the stated range (below it).
By their numbers in this assay, from the lowest: compound 3; then compounds 2 and 1 (each within the scatter of the next).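

In this assay, the aryl group on the aromatic carbon next to the ring oxygen proves to be a highly sensitive part of the molecule: 4-methoxy-3-methylphenyl in place of 3-fluoro-4-methylphenyl gives a 30-fold lower number from compound 2 to compound 3 (1.47 log units; beyond the scatter). The same holds against the simpler 3-fluorophenyl group, with a 31-fold lower number from compound 1 to compound 3 (1.49 log units; beyond the scatter), whereas the earlier methyl step, a 1.0-fold lower number from compound 1 to compound 2 (0.02 log units; within the scatter), gave no sign that changes on this ring could matter so much. No measurement here gives a reason for these large steps.

The step from compound 2 to compound 3 changes several things at once, since the fluorine leaves, a methoxy group enters and the methyl group sits at a different ring position, so the compounds shown cannot say which of these changes carries the effect, or whether they work only in combination. Also open, from the compounds shown here alone, is whether the low number of compound 3 would survive with a longer ethoxy chain, a hydroxyl group or a dimethylamino group in place of the methoxy group.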